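The source may report more compounds than this note shows. Statements on the series, on what has been measured and on what is new or still open speak of the compounds shown alone.

Measured so far:
Compound 1, `COc1cc(C(=O)/C=C\Nc2ccc(-c3nc4cc(OC)c(OC)c(OC)c4s3)cc2C)cc([N+](=O)[O-])c1OC`: 12800 nM
Compound 2, `COc1cc(OC)c2sc(-c3ccc(N/C=C\C(=O)c4ccc(OC)c([N+](=O)[O-])c4)c(C)c3)nc2c1`: 10800 nM
Compound 3, `COc1ccc(C(=O)/C=C\Nc2ccc(-c3nc4cc(OC)c(OC)c(OC)c4s3)cc2C)cc1[N+](=O)[O-]`: 12400 nM

These three compounds share one core and differ only in the ring attached to the carbonyl carbon. In a functional assay on MDA-MB-231 cells (Homo sapiens) for antiproliferative activity, read by sulforhodamine B assay, with a stated time of 48 h (a higher number here means a weaker inhibitor, a lower number a stronger inhibitor), compound 3 stands second highest of the three numbers, yet both its neighbours sit within the scatter of it: a 1.0-fold lower number from compound 1 to compound 3 (0.01 log units; within the scatter) and a 1.1-fold higher number from compound 2 to compound 3 (0.06 log units; within the scatter). Neither removing nor adding a methoxy on that aromatic ring moved the number beyond what repeated measurements would show.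

Compound 4, `COc1cc(C(=O)/C=C\Nc2ccc(-c3nc4cc(OC)c(OC)c(OC)c4s3)cc2C)cc(OC)c1OC`, carries a larger change at the same place: 3,4,5-trimethoxyphenyl in place of 4-methoxy-3-nitrophenyl on a carbonyl carbon. Here the nitro group leaves entirely and two methoxy groups enter, so the two measured steps, both methoxy swaps, bear on it only in part. They give no sign that alterations on this ring matter, so the expected step in this assay is small, with no clear direction. The estimated step is a 1.2-fold lower number from compound 3 to compound 4 (0.09 log units; within the scatter). Going by the values given here, compound 4 is therefore expected to give about 10000 nM, within a range from 2500 nM to 40000 nM, the width reflecting that the nitro loss has no measured precedent.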

Compound 4, half-maximal inhibitory concentration: 12900 nM
Beside the measured number, compound 4's estimate is 1.3-fold (0.11 log units) below it; the measured number falls inside the stated range.
By their numbers in this assay, from the lowest: compounds 2, 3, 1 and 4 (each within the scatter of the next).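

In this assay, 3,4,5-trimethoxyphenyl in place of 4-methoxy-3-nitrophenyl on a carbonyl carbon gives a 1.0-fold higher number from compound 3 to compound 4 (0.02 log units; within the scatter) and so stays within the scatter, which shows that this ring can lose its nitro group altogether without a measurable shift. Going by these compounds alone, the single swap of methoxy in place of nitro on an aromatic carbon reads the same way, with a 1.0-fold higher number from compound 1 to compound 4 (0.00 log units; within the scatter) and again within the scatter, so the earlier methoxy steps now have a nitro counterpart. Nothing measured here explains why the number holds steady through these changes.

From the compounds shown here alone, what an amine or a carboxylic acid on this ring would do remains open, as does a longer chain in place of the ring. Going by these compounds, all the changes compared here sit on this one ring, so the contribution of the rest of the molecule also stays open.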